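Trimming the amide group from compound 2 to compound 3

This account rests on a few compounds, and the source may have more. Where it says the series, first, only, none or still open, it means among the compounds named here.

compound 1 `COc1cccc(OC)c1C(=O)Nc1c[nH]nc1C(=O)N[C@H]1CC[C@H](OC)CC1` gives 31000 nM
compound 2 `COc1cccc(OC)c1C(=O)Nc1c[nH]nc1C(=O)NC1CC2CCC1C2` gives > 50000 nM

In an ADME assay on MRC5 cells (Homo sapiens) for inhibition, with a stated time of 72 h (a higher number here means that more compound is needed for the effect, a lower number that less compound is needed), compound 2 reads > 50000 nM, which is a limit of the assay and not a number.

Compound 3 `COc1cccc(OC)c1C(=O)Nc1c[nH]nc1C(=O)NC1CCC1` changes the group on the amide-type nitrogen: a group of 4 heavy atoms (4 carbon; one four-membered non-aromatic ring of carbon only) in place of a group of 7 heavy atoms (7 carbon; 2 five-membered non-aromatic rings of carbon only), on an amide-type nitrogen.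

For the measured compounds named here, only one measured step bears on this change, also at that nitrogen: an at least 1.6-fold higher number from compound 1 to compound 2 (0.20 log units; that floor lies within the scatter). On that single step, no change beyond the scatter is expected in this assay, and the assay may again report only a limit.

The expected step is an at least 1.2-fold lower number from compound 2 to compound 3 (0.09 log units; that floor lies within the scatter).

Compound 3 is estimated at 40000 nM, with a range of 20000 nM to 50000 nM.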

Compound 3, half-maximal effective concentration: > 50000 nM
Compound 3 ended at the assay's limit; the forecaster's own chance of this, stated with the estimate: 50%; middle value at least 1.2-fold (0.09 log units) from the limit.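

The step between compound 2 and compound 3 cannot be read, because both values are limits of this assay: the limit of > 50000 nM in this assay, at which 2 of the 3 values shown sit.

The smaller cyclobutyl therefore ends at the same limit as the two-ring group of compound 2. Replacing 4-methoxycyclohexyl with cyclobutyl gives an at least 1.6-fold higher number from compound 1 to compound 3 (0.20 log units; that floor lies within the scatter), so this change is not shown to go beyond the scatter.

As far as these compounds go, how far compound 2 and compound 3 truly lie from each other stays open. So does whether a cyclohexyl group carrying an amine or a carboxylic acid on this nitrogen would give a readable number.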